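The source may hold more compounds than are shown below. What is called first, only, known or untested is meant among the compounds shown, and "the series" means these compounds.

Measured in a physicochemical assay for lipophilicity, measured as octanol-water partition; a lower number here means a more polar compound, a higher number a more lipophilic compound:
- compound 1 `CC1=C(C(=O)OCc2ccccn2)C(c2cccc(O)c2)C2=C(CCCC2=O)N1`: 1.58
- compound 2 `CC1=C(C(=O)OCc2ccccn2)C(c2ccc(Br)cc2)C2=C(CCCC2=O)N1`: 2.42
- compound 3 `CC1=C(C(=O)OCc2ccccn2)C(c2ccc([N+](=O)[O-])cc2)C2=C(CCCC2=O)N1`: 1.88

In this assay, compound 3 stands clearly apart from the bromo compound, with a number 0.54 log units lower from compound 2 to compound 3 (beyond the scatter). Its closest neighbour gives a number 0.30 log units higher from compound 1 to compound 3 (within the scatter).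

Compound 4 `CC1=C(C(=O)OCc2ccccn2)C(c2ccc(O)cc2)C2=C(CCCC2=O)N1` differs from compound 3 by hydroxy in place of nitro on an aromatic carbon, or 4-nitrophenyl to 4-hydroxyphenyl.

The measured step nearest to this change is a number 0.30 log units higher from compound 1 to compound 3 (within the scatter), which runs in the opposite direction and starts from 3-hydroxyphenyl rather than 4-hydroxyphenyl. A small fall of similar size is therefore expected, around the edge of the scatter. The estimated step is a number 0.28 log units lower from compound 3 to compound 4 (within the scatter). Compound 4 is expected at 1.6, with an estimated range from 1.25 to 1.95.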

Compound 4, partition coefficient: 1.58
Estimate against measurement, compound 4: 0.02 log units above, and the stated range covers the measured number.
By their numbers in this assay, from the lowest: compounds 1, 4 and 3 (each within the scatter of the next); then compound 2.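

In this assay 4-hydroxyphenyl in place of 3-hydroxyphenyl gives no change at the digits printed from compound 1 to compound 4 (within the scatter) and so leaves compound 1 and compound 4 indistinguishable. Hydroxy in place of bromo gives a number 0.84 log units lower from compound 2 to compound 4 (beyond the scatter) while hydroxy in place of nitro gives a number 0.30 log units lower from compound 3 to compound 4 (within the scatter) and thus compound 2 alone stands clear of the other three. Nothing available explains these differences.

Where an amine or a carboxylic acid on the same aromatic carbon would fall in this assay remains open. So does whether these steps would hold on a core with a different ester chain.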